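Amide nitrogen substituent in a dihydrofuran carboxamide series

The source may report more compounds than this note shows. Statements on the series, on what has been measured and on what is new or still open speak of the compounds shown alone.

Compound 2 `C=CC1=C(C(=O)NC2CCCCC2)C(c2ccc(OC)c(OC)c2)OC1` and compound 3 `C=CC1=C(C(=O)NC2CCCCC2)C(c2ccc(F)cc2)OC1` both carry cyclohexyl on the amide nitrogen; the difference between the two cores is not broken down here. In a functional assay on QGY7701 cells (Homo sapiens) for cytotoxicity, read by MTT assay, with a stated time of 24 h (a lower number here means a stronger inhibitor, a higher number a weaker inhibitor), compound 2 gives 7490 nM. In this assay compound 3 gives 40500 nM. Compound 1 `C=CC1=C(C(=O)NCCC)C(c2ccc(F)cc2)OC1` is the propyl analogue of compound 3; in this assay compound 1 reaches only a limit of the assay, > 100000 nM, at the limit of > 100000 nM in this assay, at which 1 of the 3 values shown sits. The measured step is an at least 2.4-fold higher number from compound 3 to compound 1 (0.39 log units; beyond the scatter), described by propyl in place of cyclohexyl on an amide-type nitrogen.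

Compound 4 `C=CC1=C(C(=O)NCCC)C(c2ccc(OC)c(OC)c2)OC1` is the same change applied to compound 2: propyl in place of cyclohexyl on an amide-type nitrogen. The two place lines agree word for word, so the change is the same. On the core of compound 2 the step is expected to run in the same direction, a 3.3-fold higher number from compound 2 to compound 4 (0.52 log units; beyond the scatter), resting on the step of an at least 2.4-fold higher number from compound 3 to compound 1 (0.39 log units; beyond the scatter) and on the value of compound 2, 7490 nM. In this assay compound 4 is therefore estimated at 25000 nM, with a range from 10000 nM to 100000 nM.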

Compound 4, half-maximal inhibitory concentration: > 100000 nM
Compound 4: no number, only a limit; the forecaster's own chance of this, stated with the estimate: 20%; middle value at least 4.0-fold (0.60 log units) from the limit.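

Compound 4 reaches only a limit of the assay in this assay, at > 100000 nM. Propyl in place of cyclohexyl on an amide-type nitrogen now gives an at least 13-fold higher number from compound 2 to compound 4 (1.12 log units; beyond the scatter), so on the two cores shown the change runs in the same direction and carries over in that sense. What does not follow is that the change has the same size on both cores, and no larger effect on one core can be claimed: the same change on two cores in this assay, an at least 2.4-fold higher number (0.39 log units; beyond the scatter) from compound 3 to compound 1 and an at least 13-fold higher number (1.12 log units; beyond the scatter) from compound 2 to compound 4; the limit leaves it open whether they differ

Going by these compounds, compound 1 and compound 4 both rest at a limit, so the two propyl amides cannot be placed relative to each other, and how far activity falls with propyl on either core stays unresolved: the limit of > 100000 nM in this assay, at which 2 of the 4 values shown sit. Also open is what other groups on the amide nitrogen would give in place of cyclohexyl, such as cyclopentyl, a longer chain like hexyl, or a cyclohexyl ring carrying an amine.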